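Hydroxyphenyl isomers in the series: compound 3 to compound 4

A few compounds are considered here, and "the series" means these few. Any claim that something is new, unique, unknown or untested is made for them only; others in the source may bear on it.

Measured in an ADME assay on microsomes from liver (Homo sapiens) for metabolic stability, read by LC-MS, with a stated time of 30 min, tested at 0.5 uM; on this read-out higher numbers stand for a more stable compound and lower numbers for a less stable compound:
- compound 1 `c1ccc(-c2cc(-c3csc(N=C4NCCCN4)n3)cs2)cc1`: 70%
- compound 2 `c1ccc(-c2nc(-c3csc(N=C4NCCCN4)n3)cs2)cc1`: 83%
- compound 3 `Oc1ccc(-c2nc(-c3csc(N=C4NCCCN4)n3)cs2)cc1`: 86%

Compound 3 gives 86%, and compound 2 at 83% lies within the scatter of it. Compound 1 at 70% stands lower than compound 3, beyond the scatter.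

The next compound to be read is compound 4 `Oc1cccc(-c2nc(-c3csc(N=C4NCCCN4)n3)cs2)c1`, which has the same atoms as compound 3, joined differently. It carries 3-hydroxyphenyl in place of 4-hydroxyphenyl on an aromatic carbon of the five-membered aromatic ring with 1 nitrogen and 1 sulfur (3-hydroxyphenyl in place of 4-hydroxyphenyl on an aromatic carbon).

Among the measured compounds shown here, one measured step bears on this change: a number 3 percentage points higher from compound 2 to compound 3 (within the scatter), with hydroxy in place of hydrogen on an aromatic carbon. That step stays within the scatter. For the measured compounds named here, no measured pair shows the hydroxy group at two different places, so the data give only indirect guidance.

With so small a step on record, no shift beyond the scatter is expected in this assay, and the estimate is a number 2 percentage points lower from compound 3 to compound 4 (within the scatter). Compound 4 is expected at 84%, with an estimated range of 72% to 95%.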

Compound 4, percent of the compound remaining: 77%
Beside the measured number, compound 4's estimate is 7 percentage points above it; the measured number falls inside the stated range.
By their numbers in this assay, from the lowest: compounds 1, 4, 2 and 3 (each within the scatter of the next, the first and the last beyond it).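

In this assay, among the compounds shown here, 3-hydroxyphenyl in place of 4-hydroxyphenyl, on the aromatic carbon next to the ring nitrogen and next to the ring sulfur, gives a number 9 percentage points lower from compound 3 to compound 4 (within the scatter); this is the first pair that compares two places for the hydroxy group, and at this size of step the read-out does not tell the two isomers apart. Set against the plain phenyl, 3-hydroxyphenyl gives a number 6 percentage points lower from compound 2 to compound 4 (within the scatter), and 4-hydroxyphenyl gives a number 3 percentage points higher from compound 2 to compound 3 (within the scatter), so neither hydroxyphenyl isomer stands apart from the plain phenyl in this read-out. Nothing on hand gives a reason for these numbers.

Still open is whether a methoxy group, an amine or a carboxylic acid in place of the hydroxy group on the phenyl would also stay within the scatter of these compounds. Also open is whether the two hydroxyphenyl isomers would read alike on the core of compound 1, where no hydroxy-bearing partner is shown.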